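A few compounds are considered here, and "the series" means these few. Any claim that something is new, unique, unknown or untested is made for them only; others in the source may bear on it.

Compound 1 `CC#CC(CC(=O)O)c1ccc(OCc2ccn3cc(-c4ccc(C(C)C)cc4)nc3c2)cc1` is one of three compounds tested in an assay on isolated protein for agonist activity at Free fatty acid receptor 1 (Homo sapiens) (on this read-out lower numbers stand for an effect already at smaller amounts and higher numbers for an effect only at larger amounts of compound), where compound 1 gives 615 nM. The two others are compound 2 `CC#CC(CC(=O)O)c1ccc(OCc2ccc3nc(-c4ccc(F)cc4F)cn3c2)cc1`, which gives 825 nM, and compound 3 `CC#CC(CC(=O)O)c1ccc(OCc2ccc3nc(-c4ccc(C(C)C)cc4)cn3c2)cc1`, which gives 528 nM. On the numbers alone compound 1 stands second of the three, but its gaps to compound 3 and to compound 2 both lie within the usual scatter, so the three cannot be told apart. For the measured compounds named here, the only single-point step among them, a 1.6-fold lower number from compound 2 to compound 3 (0.19 log units; within the scatter), replaced 2,4-difluorophenyl with 4-isopropylphenyl and stayed within the scatter.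

Compound 4 `CC#CC(CC(=O)O)c1ccc(OCc2ccn3cc(-c4ccc(C(F)(F)F)cc4)nc3c2)cc1` has not been measured yet. It differs from compound 1 by trifluoromethyl in place of isopropyl on an aromatic carbon. The step from compound 2 to compound 3 is the only measured one that touches this outer aromatic ring, and it was small, so no change beyond the scatter is expected in this assay for compound 4 either. Compound 4 is therefore expected to give about 700 nM, between 300 nM and 1600 nM, which means an expected step of a 1.1-fold higher number from compound 1 to compound 4 (0.06 log units; within the scatter).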

Compound 4, half-maximal effective concentration: 674 nM
For compound 4 the middle estimate is 1.0-fold (0.02 log units) above the measured one; the measured number falls inside the stated range.
By their numbers in this assay, from the lowest: compounds 3, 1, 4 and 2 (each within the scatter of the next).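

In this assay, putting trifluoromethyl in place of isopropyl on this aromatic carbon, para to a large group, gives a 1.1-fold higher number from compound 1 to compound 4 (0.04 log units; within the scatter). The earlier step on this ring changed two fluorines for an isopropyl on the core of compound 2 and compound 3, whereas this one exchanges one group for another at a single carbon on the core of compound 1, and the read-out again stays within the scatter. Isopropyl and trifluoromethyl therefore cannot be told apart at this position, and nothing measured alongside these numbers offers an explanation.

Still open, from the compounds shown here alone, is whether this tolerance extends to a very different group here, such as an amine, a carboxylic acid or a longer chain. It is also unknown whether trifluoromethyl would behave the same way on the core of compound 3.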